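Phenyl for Cyclohexyl on the Lactone Core

The source may report more compounds than this note shows. Statements on the series, on what has been measured and on what is new or still open speak of the compounds shown alone.

Compound 1 `C=C1C(=O)O[C@@H](C2CCCCC2)[C@H]1c1ccccc1` gives 81% in a functional assay on MIA PaCa-2 cells (Homo sapiens) for cytotoxicity, read by MTT assay, with a stated time of 72 h, tested at 10 uM; a higher number here means a weaker effect of the compound at the concentration tested, a lower number a stronger effect.
Compound 2 `C/C=C1\C(=O)O[C@@H](c2ccc([N+](=O)[O-])cc2)[C@H]1C` gives 110% in this assay.

Of these two numbers compound 1 stands lower, and its gap to compound 2 lies beyond the usual scatter. Compound 3 `C=C1C(=O)O[C@@H](c2ccccc2)[C@H]1c1ccccc1` differs from compound 1 by phenyl in place of cyclohexyl on a saturated ring carbon. Nothing measured here shows the effect of such a swap on the shared core. The step expected in this assay from compound 1, as a number 4 percentage points higher from compound 1 to compound 3 (within the scatter), is small and within the scatter, in no firm direction. For compound 3 the estimated reading is 85%, likely between 62% and 105%.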

Compound 3, a percentage reported as activity, at one concentration (the size of the read-out at that concentration, not a potency): 3%
Estimate against measurement, compound 3: 82 percentage points above, and the stated range ends above it.
By their numbers in this assay, from the lowest: compound 3; then compound 1; then compound 2.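

On the saturated ring carbon next to the ring oxygen, phenyl in place of cyclohexyl gives a number 78 percentage points lower from compound 1 to compound 3 (beyond the scatter) in this assay. This position therefore responds strongly to the swap, even though both groups have the same counts of heavy atoms, hydrogen-bond donors and acceptors and differ in the aromatic ring. No evidence at hand accounts for this step.

On these data alone, whether an amine, a carboxylic acid or a longer chain on this carbon would keep the low reading remains open. Also open, as far as these compounds go, is whether the phenyl group on the other ring atom is needed for it.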